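Fluorophenyl positional isomer in the amide cytotoxicity series

The source may hold more compounds than are shown below. What is called first, only, known or untested is meant among the compounds shown, and "the series" means these compounds.

Measured compounds:
compound 1 `Cn1ccc2c(Oc3ccc(NC(=O)c4nn(-c5ccc(Cl)c(C(F)(F)F)c5)ccc4=O)cc3F)ccnc21` — 20900 nM
compound 2 `Cc1cc(=O)n(-c2ccc(F)cc2)nc1C(=O)Nc1ccc(Oc2ncnc3[nH]ccc23)cc1` — > 60000 nM

In a functional assay on PC-3 cells (Homo sapiens) for cytotoxicity, read by MTT assay, with a stated time of 72 h (on this read-out lower numbers stand for stronger inhibition and higher numbers for weaker inhibition), compound 1 gives 20900 nM. Compound 2 does not reach a number in this assay; its result is a limit of the assay, > 60000 nM, as the limit of > 60000 nM in this assay, at which 1 of the 2 values shown sits, records. Compound 2 therefore stands at the weak end of what the assay can report, and nothing more precise is known about it.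

Compound 3 `Cc1cc(=O)n(-c2cccc(F)c2)nc1C(=O)Nc1ccc(Oc2ncnc3[nH]ccc23)cc1` is the next entry. The change from compound 2 is 3-fluorophenyl in place of 4-fluorophenyl on an aromatic nitrogen. Among the measured compounds shown here, no measured pair in the set shows this kind of change, so no direction can be read from the data; with compound 2 at a limit, a step no larger than the scatter is expected in this assay, and a limit result is the more likely outcome. The step that the limit leaves unreadable from compound 2 to compound 3 is expected. Compound 3 is estimated at 70000 nM, between 30000 nM and 160000 nM.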

Compound 3, half-maximal inhibitory concentration: 14600 nM
Compound 3: the middle estimate sits 4.8-fold (0.68 log units) above what was measured; measured number below the stated range.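

In this assay, 3-fluorophenyl in place of 4-fluorophenyl on an aromatic nitrogen gives an at least 4.1-fold lower number from compound 2 to compound 3 (0.61 log units; beyond the scatter). At this position, then, where the single fluorine sits on the phenyl group is enough to separate a measured number from a result at the limit, with the atom count unchanged. The size of the step stays open on one side, as the result for compound 2 is a limit and not a number: the limit of > 60000 nM in this assay, at which 1 of the 3 values shown sits.

From the compounds shown here alone, whether 3-chlorophenyl, 3-methoxyphenyl or plain phenyl on the same aromatic nitrogen would match compound 3 remains open. This change rests on a single pair of compounds, so nothing can yet be said about how it behaves on another core, such as that of compound 1.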